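The source may hold more compounds than are shown below. What is called first, only, known or untested is meant among the compounds shown, and "the series" means these compounds.

Two compounds of the series have numbers in an ADME assay on microsomes from liver (Homo sapiens) for metabolic stability, using NADPH, with a stated time of 40 min, tested at 2 uM; on this read-out higher numbers stand for a longer-lived compound and lower numbers for a shorter-lived compound. Compound 1 `Clc1cccc2c(-c3ccc4ccccc4n3)c[nH]c12` gives 0.283 h in this assay. Compound 2 `Cc1cccc2c(-c3ccc4c(F)cccc4n3)c[nH]c12` gives 0.217 h in this assay, the lower of the two numbers; the nearest is compound 1, and the gap between the two lies within the scatter, so no order between them is claimed. Compound 3 `Cc1cccc2c(-c3ccc4ccccc4n3)c[nH]c12` has not yet been measured in this assay. It differs from compound 2 in one place: hydrogen in place of fluoro on an aromatic carbon. Within the data shown here, no step between two measured compounds isolates this change, and compounds 1 and 2 differ in more than one place, so that pair shows nothing about fluoro on its own. The step expected a 1.2-fold higher number from compound 2 to compound 3 (0.06 log units; within the scatter) is small, with no direction beyond the scatter. Compound 3 is therefore expected to give about 0.25 h in this assay, within a range of 0.13 h to 0.5 h.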

Compound 3, half-life: 0.35 h
Estimate against measurement, compound 3: 1.4-fold (0.15 log units) below, and the stated range covers the measured number.
By their numbers in this assay, from the lowest: compounds 2, 1 and 3 (each within the scatter of the next).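

With the fluoro removed, this position can now be read on its own: hydrogen in place of fluoro on an aromatic carbon, ortho to a fused ring and meta to a fused ring, gives a 1.6-fold higher number from compound 2 to compound 3 (0.21 log units; within the scatter) in this assay and so leaves the half-life within the scatter. The other single change, methyl in place of chloro on an aromatic carbon, gives a 1.2-fold higher number from compound 1 to compound 3 (0.09 log units; within the scatter) and is also within the scatter, so neither of the two swaps separates its pair of compounds on this read-out. Nothing available explains the closeness of these numbers.

On these data alone, whether an amine, a carboxylic acid or a methoxy group on the same aromatic carbon would give a number beyond the scatter remains open. Also open, as far as these compounds go, is whether any change to the shared core moves the half-life beyond the scatter in this assay at all.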